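The source may report more compounds than this note shows. Statements on the series, on what has been measured and on what is new or still open speak of the compounds shown alone.

Working notes on the series. Of the compounds shown here, three have so far been measured in an assay on isolated protein for inhibition of 2-Hydroxyacid oxidase 2 (Homo sapiens), tested at 10 uM; a lower number here means a weaker effect, a higher number a stronger effect of the compound at the concentration tested. Compound 1 `Cc1n[nH]c(C(=O)O)c1Cc1ccccc1-c1ccc(F)cc1` gives 56% in this assay. Compound 2 `Cc1n[nH]c(C(N)=O)c1Cc1cccc(-c2ccc(F)cc2)c1` gives 14% in this assay. Compound 3 `Cc1n[nH]c(C(=O)O)c1Cc1ccc(Oc2ccccc2)cc1` gives 43% in this assay, which places it second highest of the three numbers: the nearest value is that of compound 1, higher than compound 3 and beyond the scatter, and the furthest is that of compound 2, lower than compound 3 and beyond the scatter. No pair among these three differs in a single place, so no measured step is available as a guide for what follows.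

The next compound, compound 4 `Cc1n[nH]c(C(=O)O)c1Cc1ccc(C(N)=O)cc1`, shares the core of compound 3 and differs from it at one position: carbamoyl in place of phenoxy on an aromatic carbon. No comparable exchange of one group for another has been measured here, so the expected step rests only on the position of compound 3 in this assay and on the change itself. The step from compound 3 to compound 4 is expected to be a decrease beyond the scatter, a number 21 percentage points lower from compound 3 to compound 4 (beyond the scatter). Compound 4 is accordingly estimated at 22% in this assay, with a range from 5% to 42%.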

Compound 4, a percentage reported as inhibition, at one concentration (the size of the read-out at that concentration, not a potency): 8%
For compound 4 the middle estimate is 14 percentage points above the measured one, within the range that was stated.
By their numbers in this assay, from the lowest: compounds 4 and 2 (each within the scatter of the next); then compound 3; then compound 1.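

Carbamoyl in place of phenoxy on an aromatic carbon gives, in this assay, a number 35 percentage points lower from compound 3 to compound 4 (beyond the scatter), the first step in the series that can be read at a single position. The shared core, with its carboxylic acid, stays the same across this step, so the read-out depends strongly on the group at this place and is not set by the core alone. No measurement bears on the reason for the size of the step.

This one exchange removes the phenoxy with its six-membered aromatic ring, brings in a smaller group and adds a hydrogen-bond donor, and the compounds shown do not separate these changes from one another. On these data alone, it also remains open where a methoxy, a benzyloxy or an amine on this same aromatic carbon would stand in this assay, and whether a phenyl joined directly to the ring at this place would keep the read-out of the phenoxy.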